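From 4-methoxypiperidin-1-yl to (4-methoxycyclohexyl)amino

A few compounds are considered here, and "the series" means these few. Any claim that something is new, unique, unknown or untested is made for them only; others in the source may bear on it.

In a functional assay on MIA PaCa-2 cells (Homo sapiens) for inhibition, read by MTT assay, with a stated time of 3 days (a higher number here means a weaker inhibitor, a lower number a stronger inhibitor), compound 2 (`CCN(CC)S(=O)(=O)c1ccc(S(=O)(=O)N2CCC[C@@H](C(=O)N3CCC(OC)CC3)C2)cc1`) gives 50 nM as its reading. Compound 1 (`O=C([C@@H]1CCCN(S(=O)(=O)c2ccc(S(=O)(=O)N3CC[C@@H](O)C3)cc2)C1)N1CCC(F)(F)CC1`) gives 135 nM as a higher number than compound 2, a gap beyond the usual scatter of repeated measurements. Compound 3 (`CN(C)S(=O)(=O)c1ccc(S(=O)(=O)N2CCC[C@@H](C(=O)N3CCC(F)(F)CC3)C2)cc1`) gives 72.4 nM and stands within that scatter of compound 2.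

Compound 4 (`CCN(CC)S(=O)(=O)c1ccc(S(=O)(=O)N2CCC[C@@H](C(=O)N[C@H]3CC[C@@H](OC)CC3)C2)cc1`) differs from compound 2 in one place, with (4-methoxycyclohexyl)amino in place of 4-methoxypiperidin-1-yl on a carbonyl carbon. For the measured compounds named here, the only measured step in the set is a 1.9-fold lower number from compound 1 to compound 3 (0.27 log units; within the scatter) and it concerns a sulfonyl sulfur, with dimethylamino in place of 3-hydroxypyrrolidin-1-yl, not this carbonyl carbon. Going by the values given here, none of the measured compounds carries (4-methoxycyclohexyl)amino, so the size of the new step cannot be read from them.

The reading of compound 2 at 50 nM therefore remains the only anchor for the expectation, and no step beyond the scatter is expected in either direction. The expected size is a 1.2-fold higher number from compound 2 to compound 4 (0.08 log units; within the scatter), with wide uncertainty. Compound 4 is estimated at 60 nM in this assay, with an expected range from 15 nM to 240 nM.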

Compound 4, half-maximal inhibitory concentration: 590 nM
Compound 4: middle estimate off by 9.8-fold (0.99 log units), on the low side; the whole stated range lies below it.
By their numbers in this assay, from the lowest: compounds 2, 3 and 1 (each within the scatter of the next, the first and the last beyond it); then compound 4.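

In this assay, the exchange on this carbonyl carbon is far from neutral: replacing 4-methoxypiperidin-1-yl with (4-methoxycyclohexyl)amino gives a 12-fold higher number from compound 2 to compound 4 (1.07 log units; beyond the scatter). For the compounds shown here, the only earlier step, a 1.9-fold lower number from compound 1 to compound 3 (0.27 log units; within the scatter), concerned a sulfonyl sulfur, so this is the first sign in the set that the group on the carbonyl carbon can shift the reading well beyond the scatter, even though the methoxy group and a six-membered non-aromatic ring are present on both sides of the change. Nothing available here gives a measured basis for explaining the size of this step.

The change alters several features at once, replacing a ring with a hetero atom by a carbon-only ring, introducing the amide hydrogen and adding two defined stereocentres, so the compounds shown do not tell which of these goes with the higher number. A (4-methoxycyclohexyl)(methyl)amino group on the same carbonyl carbon would address the amide hydrogen, while the opposite stereoisomer of the (4-methoxycyclohexyl)amino group would address the arrangement of its ring substituents.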